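The source may hold more compounds than are shown below. What is called first, only, known or untested is meant among the compounds shown, and "the series" means these compounds.

Measured in an ADME assay on L1210/0 cells (Mus musculus) for cytotoxicity, with a stated time of 48 h; on this read-out higher numbers stand for weaker inhibition and lower numbers for stronger inhibition:
- compound 1 `O=C1O/C(=C\Cn2ccc(=O)[nH]c2=O)C(OCc2ccccc2)=C1OCc1ccccc1`: 12900 nM
- compound 2 `C=C(Cl)c1cn([C@H]2C[C@H](O)[C@@H](CO)O2)c(=O)[nH]c1=O`: 1660 nM

Compound 1 stands at 12900 nM and compound 2 at 1660 nM, the lower of the two numbers, and the gap between them lies beyond the scatter. Compound 3 `O=c1[nH]c(=O)n([C@H]2C[C@H](O)[C@@H](CO)O2)cc1C#CCCCO` is still unmeasured. It keeps the core of compound 2 and carries 5-hydroxypent-1-yn-1-yl in place of 1-chloroethenyl on an aromatic carbon. Within the data shown here, no measured pair shows a change at this place, so the expectation is loosely founded. A move to a higher number in this assay, beyond the scatter, is expected, meaning weaker inhibition. The expected size is a 15-fold higher number from compound 2 to compound 3 (1.18 log units; beyond the scatter). For compound 3 the estimate is 25000 nM, with an expected range of 3000 nM to 150000 nM.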

Compound 3, half-maximal inhibitory concentration: > 200000 nM
Compound 3 ended at the assay's limit; the forecaster's own chance of this, stated with the estimate: 20%; at least 8.0-fold (0.90 log units) between middle value and limit.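

In this assay, among these compounds, this position on the aromatic carbon turns out to be highly sensitive to the group it carries, which no earlier pair could show: replacing 1-chloroethenyl with 5-hydroxypent-1-yn-1-yl gives an at least 120-fold higher number from compound 2 to compound 3 (2.08 log units; beyond the scatter). Compound 3 gives > 200000 nM, which is a limit of the assay and not a number. The step therefore sets only a lower bound on the size of the change, and its true size remains unknown: the limit of > 200000 nM in this assay, at which 1 of the 3 values shown sits.

The change swaps the double bond for a triple bond, removes chlorine, lengthens the chain and adds a hydroxyl all at once, so the compounds shown cannot say which of these matters. Going by these compounds, whether an ethynyl group, or a pentynyl chain ending in an amine instead of the hydroxyl, would keep the inhibition of compound 2 remains open.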